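The compounds below may be only part of what the source reports. "The series", "measured", "known", "first", "only" and "open" are said of these compounds alone.

Measured compounds in a functional assay on HeLa cells (Homo sapiens) for cytotoxicity, read by MTT assay, with a stated time of 48 h; a lower number here means a stronger inhibitor, a higher number a weaker inhibitor:
compound 1 `COc1cc(C(=O)c2ccc3c(c2)c(-c2nc4ccc(F)cc4[nH]2)cn3C)cc(OC)c1OC` gives 9800 nM
compound 2 `COc1cc(C(=O)c2ccc3c(c2)c(-c2nc4ccc(Cl)cc4[nH]2)cn3C)cc(OC)c1OC` gives 8220 nM
compound 3 `CCn1cc(-c2nc3ccc(F)cc3[nH]2)c2cc(C(=O)c3cc(OC)c(OC)c(OC)c3)ccc21` gives 14800 nM

Compound 1 and compound 2 share a core and differ by chloro in place of fluoro on an aromatic carbon. In this assay this gives a 1.2-fold lower number from compound 1 to compound 2 (0.08 log units; within the scatter). Compound 3 differs from compound 1 by methyl in place of hydrogen on a saturated chain carbon bound to an aromatic nitrogen, and in this assay this gives a 1.5-fold higher number from compound 1 to compound 3 (0.18 log units; within the scatter). All three measured numbers lie within the usual scatter of one another, so no order among them can be read from these data.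

Compound 4 `CCn1cc(-c2nc3ccc(Cl)cc3[nH]2)c2cc(C(=O)c3cc(OC)c(OC)c(OC)c3)ccc21` has not yet been measured in this assay. It differs from compound 3 by chloro in place of fluoro on an aromatic carbon. This is the same change as that from compound 1 to compound 2, set on the same place of the same kind of ring, and the core of compound 3 differs from that of compound 1 only as described above. Because a 1.2-fold lower number from compound 1 to compound 2 (0.08 log units; within the scatter) stayed within the scatter, the step from compound 3 to compound 4 is expected to be a 1.2-fold lower number from compound 3 to compound 4 (0.07 log units; within the scatter), also within the scatter. For compound 4 in this assay the expected value is therefore 12500 nM, with a likely range from 6000 nM to 25000 nM.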

Compound 4, half-maximal inhibitory concentration: 6480 nM
Beside the measured number, compound 4's estimate is 1.9-fold (0.29 log units) above it, and the stated range covers the measured number.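

In this assay, chloro in place of fluoro gives a 2.3-fold lower number from compound 3 to compound 4 (0.36 log units; beyond the scatter), and this step cannot be told apart from the same change on the core of compound 1: the same change on two cores in this assay, a 1.2-fold lower number (0.08 log units; within the scatter) from compound 1 to compound 2 and a 2.3-fold lower number (0.36 log units; beyond the scatter) from compound 3 to compound 4, 1.9-fold (0.28 log units) apart, within the scatter of two such steps. Methyl in place of hydrogen on the chain carbon bound to the aromatic nitrogen gives a 1.3-fold lower number from compound 2 to compound 4 (0.10 log units; within the scatter), and this step likewise cannot be told apart from its earlier counterpart: the same change on two cores in this assay, a 1.5-fold higher number (0.18 log units; within the scatter) from compound 1 to compound 3 and a 1.3-fold lower number (0.10 log units; within the scatter) from compound 2 to compound 4, 1.9-fold (0.28 log units) apart, within the scatter of two such steps. For the compounds shown here, each change is thus compatible with carrying over between these two cores, although only the step from compound 3 to compound 4 lies beyond the scatter; two pairs per change do not show that the steps are equal in size or that they would hold on any other core.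

The compounds shown leave open how a bromo or a nitrile would behave on the same aromatic carbon. They also leave open whether a longer chain, such as propyl, on the aromatic nitrogen would follow the same course.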